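Nitrophenyl for Fluorophenyl on an Aromatic Nitrogen

The source may report more compounds than this note shows. Statements on the series, on what has been measured and on what is new or still open speak of the compounds shown alone.

Among the compounds with values here, compound 2 `COc1ccc(/C=C\C(=O)O)c(OCc2cn(-c3ccccc3F)nn2)c1CC=C(C)C` is the only compound here with a number: in a functional assay on PC-3 cells (Homo sapiens) for cytotoxicity, read by MTT assay, with a stated time of 24 h (a higher number here means a weaker inhibitor, a lower number a stronger inhibitor), compound 2 gives 24200 nM. Compound 1 `COc1ccccc1-n1cc(COc2c(/C=C\C(=O)O)ccc(OC)c2CC=C(C)C)nn1` was also prepared, but in this assay compound 1 gives "not determined" (no result reported). Compound 3 `COc1ccc(/C=C\C(=O)O)c(OCc2cn(-c3cccc([N+](=O)[O-])c3)nn2)c1CC=C(C)C` differs from compound 2 in one place: 3-nitrophenyl in place of 2-fluorophenyl on an aromatic nitrogen. Within the data shown here, no comparable step between measured compounds is available, so the data give no direction, and a step within the scatter is expected in this assay. Compound 3 is estimated at 24000 nM, with a range of 8000 nM to 70000 nM. That estimate means an expected step of a 1.0-fold lower number from compound 2 to compound 3 (0.00 log units; within the scatter).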

Compound 3, half-maximal inhibitory concentration: 42100 nM
Compound 3: the middle estimate sits 1.8-fold (0.24 log units) below what was measured; low and high end bracket the measured number.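

In this assay, within the data shown here, the only step that can be read at this aromatic nitrogen is a 1.7-fold higher number from compound 2 to compound 3 (0.24 log units; within the scatter), so the two aryl groups cannot be told apart here. This holds even though 3-nitrophenyl carries hydrogen-bond acceptors and 2-fluorophenyl carries none. Nothing shown offers an explanation for this result. As far as these compounds go, whether the position stays this indifferent to other groups remains open. An unsubstituted phenyl, an aminophenyl or a longer alkyl chain on this nitrogen could show whether anything placed here moves the number beyond the scatter.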